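The source may report more compounds than this note shows. Statements on the series, on what has been measured and on what is new or still open speak of the compounds shown alone.

In a physicochemical assay for lipophilicity, measured as octanol-water partition, at pH 7.4 (a higher number here means a more lipophilic compound, a lower number a more polar compound), three compounds have been measured:

- Compound 1 `Cc1ccc(Cn2c(=O)[nH]c3c(N)nc(C(F)(F)F)cc32)cn1`: 2.3
- Compound 2 `Cc1cc(Cn2c(=O)[nH]c3c(N)nc(C(F)(F)F)cc32)no1`: 2.1
- Compound 3 `Cc1nc(Cn2c(=O)[nH]c3c(N)nc(C(F)(F)F)cc32)co1`: 1.7

Compound 3 stands lowest of the three in this assay, as the steps show: a number 0.40 log units lower from compound 2 to compound 3 (beyond the scatter) and a number 0.60 log units lower from compound 1 to compound 3 (beyond the scatter).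

Compound 4 `Nc1ccc(Cn2c(=O)[nH]c3c(N)nc(C(F)(F)F)cc32)cn1` has not yet been measured. Its structure differs from that of compound 3 by 6-aminopyridin-3-yl in place of 2-methyl-1,3-oxazol-4-yl on a saturated chain carbon bound to an aromatic nitrogen.

Within the data shown here, no measured step makes this exact change. The closest is a number 0.60 log units lower from compound 1 to compound 3 (beyond the scatter), which, read backwards, points upward for a return to a pyridine ring. However, compound 1 carries 6-methylpyridin-3-yl rather than 6-aminopyridin-3-yl, and no measured step covers that difference, so only part of that rise is carried over. The other ring swap, a number 0.20 log units lower from compound 1 to compound 2 (within the scatter), adds little.

The expected step is a number 0.10 log units higher from compound 3 to compound 4 (within the scatter), with no change beyond the scatter anticipated. The estimate for compound 4 is 1.8, with an expected range from 1.4 to 2.2.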

Compound 4, distribution coefficient: 1.5
Beside the measured number, compound 4's estimate is 0.30 log units above it; the measured number falls inside the stated range.
By their numbers in this assay, from the lowest: compounds 4 and 3 (each within the scatter of the next); then compounds 2 and 1 (each within the scatter of the next).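

In this assay, among these compounds, amino in place of methyl on an aromatic carbon gives a number 0.80 log units lower from compound 1 to compound 4 (beyond the scatter), showing that the group carried on the pyridine ring can shift this number, whereas the earlier compounds varied only the ring itself. A pyridine ring therefore does not by itself go with the higher numbers: 6-aminopyridin-3-yl in place of 5-methyl-1,2-oxazol-3-yl gives a number 0.60 log units lower from compound 2 to compound 4 (beyond the scatter), and in place of 2-methyl-1,3-oxazol-4-yl it gives a number 0.20 log units lower from compound 3 to compound 4 (within the scatter). Nothing available here accounts for these steps.

As far as these compounds go, it remains open whether a methoxy or a dimethylamino group in place of the amino would fall nearer compound 4 or compound 1. Also open, from the compounds shown here alone, is whether amino in place of methyl on a 1,3-oxazole ring would bring a step of similar size.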